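Aryl nucleoside series: benzofuran-2-yl in place of phenyl

The compounds below may be only part of what the source reports. "The series", "measured", "known", "first", "only" and "open" are said of these compounds alone.

Measured compounds in this study:
compound 1 `COc1nc(N)nc2c1c(-c1ccccc1)cn2[C@@H]1O[C@H](CO)[C@@H](O)[C@H]1O` — > 20000 nM
compound 2 `Nc1nc(N)c2c(-c3ccccc3)cn([C@@H]3O[C@H](CO)[C@@H](O)[C@H]3O)c2n1` — > 20000 nM
compound 3 `COc1ncnc2c1c(-c1ccccc1)cn2[C@@H]1O[C@H](CO)[C@@H](O)[C@H]1O` — > 20000 nM
compound 4 `COc1nc(N)nc2c1c(-c1cc3ccccc3o1)cn2[C@@H]1O[C@H](CO)[C@@H](O)[C@H]1O` — not yet measured

In a functional assay on K562 cells (Homo sapiens), read by MTT assay, with a stated time of 72 h (on this read-out lower numbers stand for stronger inhibition and higher numbers for weaker inhibition), compound 1 gives > 20000 nM, which is a limit of the assay and not a number. Compound 2 likewise sits at a limit with > 20000 nM. Compound 3 also returns only a limit, > 20000 nM. All three values therefore rest at the limit of > 20000 nM in this assay, at which 3 of the 3 values shown sit, so the steps a step that the two limits leave unreadable from compound 1 to compound 2 and a step that the two limits leave unreadable from compound 1 to compound 3 have no readable size. Compound 4 differs from compound 1 by 1-benzofuran-2-yl in place of phenyl on an aromatic carbon. Among the compounds with values here, no measured step covers this change, and the measured steps give no usable size or direction. Compound 4 is expected to give about 15000 nM, within 3000 nM to 60000 nM, most probably again only a limit. The step of an at least 1.3-fold lower number from compound 1 to compound 4 (0.12 log units; that floor lies within the scatter) is thus expected to be small.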

Compound 4, half-maximal inhibitory concentration: 15500 nM
For compound 4 the middle estimate is 1.0-fold (0.01 log units) below the measured one, within the range that was stated.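

In this assay, within the data shown here, compound 4 gives 15500 nM, the first number that is not a limit. From the compounds shown here alone, with 1-benzofuran-2-yl in place of phenyl, the change reads as an at least 1.2-fold lower number from compound 1 to compound 4 (0.11 log units; that floor lies within the scatter), so only a floor is available and the full size of the step stays unknown. The other steps shown cannot be read, as their values rest on a limit of the assay: the limit of > 20000 nM in this assay, at which 3 of the 4 values shown sit.

Going by these compounds, what a thienyl or naphthyl group would give on this aromatic carbon stays open. On these data alone, whether amino or hydrogen in place of methoxy would change the value of compound 4 also stays open.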